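Notes on compound 4, a chain variant of compound 2

A few compounds are considered here, and "the series" means these few. Any claim that something is new, unique, unknown or untested is made for them only; others in the source may bear on it.

Measured so far in an ADME assay on microsomes from liver (Mus musculus) for metabolic stability; a higher number here means that the compound lasts longer, a lower number that the compound disappears faster:
- Compound 1 `CCn1ncc2c(F)cc(-c3ccc(C(CC)(CC)c4nnc[nH]4)c(=O)[nH]3)cc21` sits at a limit of this assay, > 3 h.
- Compound 2 `CC(C)C(c1ccc(-c2ccc3cccc(F)c3c2)[nH]c1=O)N1CCN/C1=N\C#N` gives 0.207 h.
- Compound 3 `CCn1ncc2c(F)cc(-c3ccc(C(CC)(CC)c4ncn(C)n4)c(=O)[nH]3)cc21` sits at a limit of this assay, > 3 h.

Among the compounds with values here, compound 2 therefore holds the only plain number among the three values; the other two are a limit, and the limit of > 3 h in this assay, at which 2 of the 3 values shown sit, covers them both. Within the data shown here, the single step between measured compounds, a step that the two limits leave unreadable from compound 1 to compound 3, is not readable in size and concerns the core of compound 1, not that of compound 2.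

Compound 4 `CC(C)C(CC(N)=O)c1ccc(-c2ccc3cccc(F)c3c2)[nH]c1=O` comes from compound 2 by a group of 4 heavy atoms (2 carbon, 1 nitrogen, 1 oxygen; no ring) in place of a group of 8 heavy atoms (4 carbon, 4 nitrogen; one five-membered non-aromatic ring with 2 hetero atoms), on a saturated chain carbon bound to an aromatic carbon and a saturated chain carbon. Among the measured compounds shown here, no measured step touches this kind of change, and none of the three measured compounds carries a carbamoylmethyl group, so no size or direction can be taken from the data. The estimate for compound 4 rests on the value of compound 2 alone, widened for the uncertainty of an untested change.

The step of a 1.4-fold higher number from compound 2 to compound 4 (0.16 log units; within the scatter) is expected to stay within the usual scatter. Compound 4 is estimated at 0.3 h in this assay, with a range from 0.1 h to 1 h.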

Compound 4, half-life: < 0.0667 h
Compound 4 was reported as a limit; the forecaster's own chance of this, stated with the estimate: 5%; middle value at least 4.4-fold (0.65 log units) away from the limit.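

In this assay, the saturated chain carbon bound to an aromatic carbon and a saturated chain carbon proves sensitive to the group it carries: carbamoylmethyl in place of the group with the five-membered non-aromatic ring gives an at least 3.1-fold lower number from compound 2 to compound 4 (0.49 log units; beyond the scatter). Within the data shown here, this is the first readable step at this position, and it goes downward, beyond the scatter. As far as these compounds go, its full size stays unknown, as compound 4 gives a limit and not a number: the limit of < 0.0667 h in this assay, at which 1 of the 4 values shown sits.

From the compounds shown here alone, whether the drop goes with the loss of the ring, the loss of the nitrile or the arrival of the carbamoylmethyl group stays open, and a carboxylic acid or a simple amine on the same chain carbon would help to separate these. The step between the two compounds on the other core cannot be read, so it adds nothing here.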